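Phenyl to (1-methylcyclopropyl)methyl: working notes on the series

The source may hold more compounds than are shown below. What is called first, only, known or untested is meant among the compounds shown, and "the series" means these compounds.

In a functional assay on a cell-free system (plasma, Homo sapiens), with a stated time of 3 min (a higher number here means a weaker inhibitor, a lower number a stronger inhibitor), compound 1 `O=C(NCc1cc(Cl)ccc1-n1cnnn1)[C@@H]1CC=NN1C(=O)[C@H](O)c1ccccc1F` gives 1100 nM. For the measured compounds named here, compound 2 `O=C(NCc1cc(Cl)ccc1-n1cnnn1)[C@@H]1CC=NN1C(=O)[C@H](O)c1ccccc1` gives 840 nM, which stands level with compound 1, the only other measured compound. Compound 3 `CC1(C[C@@H](O)C(=O)N2N=CC[C@H]2C(=O)NCc2cc(Cl)ccc2-n2cnnn2)CC1` has (1-methylcyclopropyl)methyl in place of phenyl on a saturated chain carbon bound to a carbonyl carbon and an oxygen on a saturated carbon.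

Going by the values given here, only one measured step is available as a guide: a 1.3-fold lower number from compound 1 to compound 2 (0.12 log units; within the scatter), with hydrogen in place of fluoro on an aromatic carbon. It bears only weakly on the new change, since both of its compounds keep an aromatic ring at the place where compound 3 has none. Among the compounds with values here, no measured compound shows what happens when that ring is removed, so the data fix no direction in this assay. The expected change is therefore none beyond the scatter, and the estimated step is a 1.4-fold higher number from compound 2 to compound 3 (0.15 log units; within the scatter), with real uncertainty on either side. For compound 3 the estimated value is 1200 nM, with an expected range of 350 nM to 4500 nM.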

Compound 3, half-maximal inhibitory concentration: 730 nM
For compound 3 the middle estimate is 1.6-fold (0.22 log units) above the measured one, within the range that was stated.
By their numbers in this assay, from the lowest: compounds 3, 2 and 1 (each within the scatter of the next).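

In this assay, the aromatic ring at this place turns out not to be needed for activity in this range: (1-methylcyclopropyl)methyl in place of phenyl on a saturated chain carbon bound to a carbonyl carbon and an oxygen on a saturated carbon gives a 1.2-fold lower number from compound 2 to compound 3 (0.06 log units; within the scatter), and the same exchange for 2-fluorophenyl gives a 1.5-fold lower number from compound 1 to compound 3 (0.18 log units; within the scatter). Compounds 1 and 2 both kept an aromatic ring here, so they could only show that a fluoro on that ring made no difference beyond the scatter, whereas compound 3 shows that the position also accepts a non-aromatic group with a three-membered ring and one heavy atom fewer than phenyl. Nothing available on these compounds accounts for this result, so the tolerance stands as an observation only.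

All three compounds lie within the scatter of one another, so the position has so far shown no direction in which the number moves, and a group that shifts it beyond the scatter is still to be found. From the compounds shown here alone, whether a cyclohexyl ring, a longer chain, an amine or a carboxylic acid at this place would do so remains open, as does the effect of the neighbouring hydroxyl, which all three compounds keep.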